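A few compounds are considered here, and "the series" means these few. Any claim that something is new, unique, unknown or untested is made for them only; others in the source may bear on it.

Measured in a functional assay on MDA-MB-231 cells (Homo sapiens) for cytotoxicity, read by MTT assay; a higher number here means a weaker inhibitor, a lower number a stronger inhibitor:
- compound 1 `COc1cc(/C=C2\CCC/C(=C\c3ccccc3[N+](=O)[O-])C2=O)cc(Br)c1OC`: 8.99 ug/mL
- compound 2 `CCCOc1c(Br)cc(/C=C2\CCC/C(=C\c3ccccc3[N+](=O)[O-])C2=O)cc1OC`: 1.99 ug/mL

Compound 2 holds the lower of the two numbers. Compound 3 `CCCOc1c(Br)cc(/C=C2\CCC/C(=C\c3ccc([N+](=O)[O-])cc3)C2=O)cc1OC` has not yet been measured and differs from compound 2 at one place: 4-nitrophenyl in place of 2-nitrophenyl on a double-bonded chain carbon bound to a double-bonded ring carbon. This puts 4-nitrophenyl in place of 2-nitrophenyl on a double-bonded chain carbon bound to a double-bonded ring carbon. Within the data shown here, the only measured step, a 4.5-fold lower number from compound 1 to compound 2 (0.65 log units; beyond the scatter), was made at a different place, on a saturated chain carbon bound to an oxygen on an aromatic ring. It therefore offers only a rough gauge of size, and no measurement shows the direction for this change. No firm shift beyond the scatter is expected, and the expected change is a 1.4-fold higher number from compound 2 to compound 3 (0.15 log units; within the scatter). For compound 3 the estimated value is 2.8 ug/mL, with an expected range from 0.9 ug/mL to 9 ug/mL.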

Compound 3, half-maximal inhibitory concentration: 4.01 ug/mL
Compound 3: the middle estimate sits 1.4-fold (0.16 log units) below what was measured; low and high end bracket the measured number.
By their numbers in this assay, from the lowest: compounds 2 and 3 (each within the scatter of the next); then compound 1.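

In this assay, the change at this position, 4-nitrophenyl in place of 2-nitrophenyl on a double-bonded chain carbon bound to a double-bonded ring carbon, gives a 2.0-fold higher number from compound 2 to compound 3 (0.30 log units; within the scatter) and so cannot be told apart from repeat-measurement noise. Among these compounds, this is the first reading at this position, as the earlier step concerned only a saturated chain carbon bound to an oxygen on an aromatic ring, and it shows that compound 2 and compound 3 stand level despite the two nitrophenyl groups being joined differently. Nothing available accounts for this result.

On these data alone, whether the nitro group matters at all here remains open, as does what an amine or a carboxylic acid in its place on the phenyl ring would do. As far as these compounds go, it is also open whether a longer chain on the oxygen would carry the earlier step further.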